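The source may report more compounds than this note shows. Statements on the series, on what has been measured and on what is new or still open speak of the compounds shown alone.

In an ADME assay on HepG2 cells (Homo sapiens) for cytotoxicity, with a stated time of 72 h (a lower number here means that less compound is needed, a higher number that more compound is needed for the effect), compound 1 `COC(=O)C1CCN(c2cc(Cl)c(C(=O)Nc3cc(-c4nc5ccccc5s4)ccc3C)cc2[N+](=O)[O-])CC1` reads > 25000 nM, and this is a limit of the assay, not a number. Compound 3 `O=C(Nc1ccccc1-c1nc2ccccc2s1)c1cc([N+](=O)[O-])ccc1Cl` reads > 27000 nM, likewise a limit. Compound 2 `O=C(Nc1nc(-c2cccc(F)c2)cs1)c1cc([N+](=O)[O-])ccc1Cl` gives a number, 18000 nM. Compound 1 thus stands with compound 3 as one of the two compounds known only by a limit. Compound 4 `Cc1ccc(-c2nc3ccccc3s2)cc1NC(=O)c1cc([N+](=O)[O-])ccc1Cl` differs from compound 1 by one change: hydrogen in place of 4-(methoxycarbonyl)piperidin-1-yl on an aromatic carbon. Going by the values given here, no measured step offers a guide, so only a small change is expected, and the estimated step of an at least 1.2-fold lower number from compound 1 to compound 4 (0.09 log units; that floor lies within the scatter) lies near the scatter, towards less compound needed. Compound 4 is expected at 20000 nM, with an estimated range of 8000 nM to 40000 nM.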

Compound 4, half-maximal effective concentration: > 14000 nM
Compound 4: no number, only a limit; the forecaster's own chance of this, stated with the estimate: 55%; the middle value does not contradict the limit.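

Compound 1 reads > 25000 nM, which is a limit. Going by these compounds alone, compound 4 reads > 14000 nM, also a limit, so no step between them can be read. The compounds shown leave open whether hydrogen in place of 4-(methoxycarbonyl)piperidin-1-yl shifts the read-out at all.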